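Varying the heteroaryl group on the sulfoxide-bearing carbon

The source may hold more compounds than are shown below. What is called first, only, known or untested is meant among the compounds shown, and "the series" means these compounds.

The three measured compounds share a diphenylmethyl sulfoxide core and differ only in the heteroaryl group on a saturated chain carbon bound to a sulfur. Compound 3 `[O-][S+](Cc1cc(C2CC2)on1)C(c1ccccc1)c1ccccc1` gives 38600 nM in an assay on HEK293 cells for inhibition of sodium-dependent dopamine transporter (Homo sapiens), read by scintillation counting, with stated times of 5 min and 1 min; a higher number here means a weaker inhibitor, a lower number a stronger inhibitor; this is the lowest of the three numbers, though compound 1 `CC(C)c1nnsc1C[S+]([O-])C(c1ccccc1)c1ccccc1` with 69100 nM lies within the scatter of it (a 1.8-fold lower number from compound 1 to compound 3 (0.25 log units; within the scatter)). Compound 2 `Cc1cnc(C[S+]([O-])C(c2ccccc2)c2ccccc2)nc1` gives 156000 nM, and the step of a 4.0-fold lower number from compound 2 to compound 3 (0.61 log units; beyond the scatter) is beyond the scatter, as is a 2.3-fold higher number from compound 1 to compound 2 (0.35 log units; beyond the scatter).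

Compound 4 `O=c1[nH]nc(C[S+]([O-])C(c2ccccc2)c2ccccc2)s1` carries a further heteroaryl variation at the same place: a group of 6 heavy atoms (2 carbon, 2 nitrogen, 1 oxygen, 1 sulfur; one five-membered aromatic ring with 3 hetero atoms) in place of a group of 8 heavy atoms (6 carbon, 1 nitrogen, 1 oxygen; one three-membered non-aromatic ring of carbon only, one five-membered aromatic ring with 2 hetero atoms), on a saturated chain carbon bound to a sulfur. Going by the values given here, the steps that bear on this change are the three heteroaryl exchanges above, all of them modest in either direction. The exchange that entered a group with more hetero atoms and no carbon substituent, from compound 3 to compound 2, gave a higher number; by analogy a higher number is expected for compound 4 in this assay, of a size comparable to that step rather than beyond it.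

Compound 4 is therefore estimated at 110000 nM, with a range of 35000 nM to 350000 nM, which would mean an expected step of a 2.8-fold higher number from compound 3 to compound 4 (0.45 log units; beyond the scatter).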

Compound 4, half-maximal inhibitory concentration: 38100 nM
For compound 4 the middle estimate is 2.9-fold (0.46 log units) above the measured one; the measured number falls inside the stated range.
By their numbers in this assay, from the lowest: compounds 4, 3 and 1 (each within the scatter of the next); then compound 2.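

At this place, on a saturated chain carbon bound to a sulfur, compound 4 shows that a smaller ring group with a hydrogen-bond donor and a double bond outside aromatic rings can replace 5-cyclopropyl-1,2-oxazol-3-yl with no readable change in this assay (a 1.0-fold lower number from compound 3 to compound 4 (0.01 log units; within the scatter)). Going by these compounds alone, the same holds against the 4-isopropyl-1,2,3-thiadiazol-5-yl group (a 1.8-fold lower number from compound 1 to compound 4 (0.26 log units; within the scatter)), while the 5-methylpyrimidin-2-yl group remains the one exchange that separates clearly (a 4.1-fold lower number from compound 2 to compound 4 (0.61 log units; beyond the scatter)). Among these four compounds, then, the cyclopropyl group is not needed to keep the number at the level of compound 3, and gaining a hydrogen-bond donor neither helps nor harms within the scatter, so compound 2 alone stands apart from the other three.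

On these data alone, whether an amine, a carboxylic acid or a plain phenyl ring on the same carbon would bring the number clearly under the level shared by compounds 1, 3 and 4 remains open. The data shown offer no measurement that accounts for any of these steps.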